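Hydroxy for Amino on a Butyl Chain in Two Cores

The source may report more compounds than this note shows. Statements on the series, on what has been measured and on what is new or still open speak of the compounds shown alone.

Measured so far:
compound 1, `NCCCCNc1nc(Nc2ccc(Oc3nccs3)cc2)c2ncn(C3CCCC3)c2n1`, 5980 nM
compound 2, `OCCCCNc1nc(Nc2ccc(Oc3nccs3)cc2)c2ncn(C3CCCC3)c2n1`, 6080 nM
compound 3, `NCCCCNc1nc(Nc2ccc(N3CCN(Cc4ccccc4)CC3)cc2)c2ncn(CCCO)c2n1`, 2570 nM

In a functional assay on K562 cells (Homo sapiens) for inhibition, read by fluorescence and resazurin assay, with a stated time of 72 h (on this read-out higher numbers stand for weaker inhibition of growth and lower numbers for stronger inhibition of growth), compound 1 gives 5980 nM. Compound 2 carries hydroxy in place of amino on a saturated chain carbon, four bonds along the chain from a nitrogen on an aromatic ring, and this change made a step of a 1.0-fold higher number from compound 1 to compound 2 (0.01 log units; within the scatter). Compound 3 rests on a different core; the difference between the two cores is not broken down here. In this assay compound 3 gives 2570 nM, the lowest of the three numbers, with its steps to compound 1 and compound 2 both beyond the scatter.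

Compound 4, `OCCCCNc1nc(Nc2ccc(N3CCN(Cc4ccccc4)CC3)cc2)c2ncn(CCCO)c2n1`, is to be measured in this assay. It differs from compound 3 by hydroxy in place of amino on a saturated chain carbon, four bonds along the chain from a nitrogen on an aromatic ring, the same change that separates compound 1 from compound 2, at the same place. Because the earlier step was a 1.0-fold higher number from compound 1 to compound 2 (0.01 log units; within the scatter), the step from compound 3 to compound 4 is expected to be about as small, near a 1.1-fold higher number from compound 3 to compound 4 (0.02 log units; within the scatter), resting on that single precedent. Compound 4 is therefore estimated at 2700 nM, with a range from 1400 nM to 5500 nM.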

Compound 4, concentration for 50% growth inhibition: 8670 nM
Compound 4: middle estimate off by 3.2-fold (0.51 log units), on the low side, and the stated range ends below it.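

In this assay, hydroxy in place of amino on the same chain carbon gave a 3.4-fold higher number from compound 3 to compound 4 (0.53 log units; beyond the scatter), so the step seen on the core of compound 1 did not carry over at the same size to the core of compound 3: the same change on two cores in this assay, a 1.0-fold higher number (0.01 log units; within the scatter) from compound 1 to compound 2 and a 3.4-fold higher number (0.53 log units; beyond the scatter) from compound 3 to compound 4, 3.3-fold (0.52 log units) apart, beyond the scatter of two such steps.
On the core of compound 1 the change left the number within the scatter, whereas on the core of compound 3 it weakened inhibition of growth, which shows that in this series the size of this step depends on the core that carries it.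
Among these compounds, the result does not show which of the differences between the two cores is responsible, or why the steps part, since each core offers only one pair and a single read-out.

The compounds shown leave open how the change would behave on a third core. They also leave open whether a longer chain, or a carboxylic acid or a methyl ether in place of the amino group, would follow either step.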